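Azepanyl side chain on the chlorobenzyl phthalazinone

The source may hold more compounds than are shown below. What is called first, only, known or untested is meant among the compounds shown, and "the series" means these compounds.

Measured compounds in an assay for binding affinity to Alpha-1A adrenergic receptor (Homo sapiens); on this read-out lower numbers stand for stronger inhibition and higher numbers for weaker inhibition:
compound 1 `CN1CCC[C@@H]1Cn1nc(CC2CCCCC2)c2ccccc2c1=O`, > 1990 nM;
compound 2 `CN1CCC[C@@H]1Cn1nc(Cc2ccc(F)c(F)c2)c2ccccc2c1=O`, 200 nM;
compound 3 `CN(C)CCn1nc(Cc2ccc(Cl)cc2)c2ccccc2c1=O`, 158 nM.

The value of compound 1 is a limit of this assay, not a number (the limit of > 1990 nM in this assay, at which 1 of the 3 values shown sits). Compound 3 holds the lowest of the two numbers shown; compound 2 sits within the scatter of it, so no order between the two can be drawn. Compound 2 and compound 3 differ in two places, in the amine side chain and in the aryl group, so their values are compared only as they stand.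

Compound 4 `CN1CCCCC(n2nc(Cc3ccc(Cl)cc3)c3ccccc3c2=O)C1` is not yet measured. Relative to compound 3 the change is 1-methylazepan-3-yl in place of 2-(dimethylamino)ethyl on an aromatic nitrogen.

Going by the values given here, the only measured step, an at least 9.9-fold lower number from compound 1 to compound 2 (0.99 log units; beyond the scatter), concerns the aryl group on the benzylic carbon and not the amine side chain, so it does not bear on this change. Within the shown compounds, the pyrrolidinylmethyl side chain of compound 2 and the dimethylaminoethyl side chain of compound 3 give values within the scatter of each other, which is the only hint that the basic side chain tolerates variation here. The step to compound 4 is therefore expected to stay within the scatter, a 1.3-fold higher number from compound 3 to compound 4 (0.10 log units; within the scatter).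

Compound 4 is estimated at 200 nM, between 60 nM and 700 nM.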

Compound 4, inhibition constant: 158 nM
Compound 4: the middle estimate sits 1.3-fold (0.10 log units) above what was measured; the measured number falls inside the stated range.
By their numbers in this assay, from the lowest: compounds 3, 4 and 2 (each within the scatter of the next). At a limit, above all of these: compound 1.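

Placing 1-methylazepan-3-yl in place of 2-(dimethylamino)ethyl on the aromatic nitrogen gives no change at the digits printed from compound 3 to compound 4 (within the scatter) in this assay. Going by these compounds alone, this is the first comparison of side chains on this nitrogen with the 4-chlorobenzyl group held fixed, whereas the earlier pair of compound 2 and compound 3 differed in two places. It shows that, for this one pair, an open chain of 5 heavy atoms and a seven-membered non-aromatic ring of 8 heavy atoms in total cannot be told apart on this read-out, and nothing at hand gives a reason for that result.

The compounds shown carry only a tertiary amine on this nitrogen, so it stays open how a secondary amine such as the azepan-3-yl group without its methyl, a side chain with no amine such as a plain butyl chain, or a carboxylic acid would read. Also open, going by these compounds, is whether the azepanyl side chain reads the same with the 3,4-difluorophenyl group of compound 2 in place of the 4-chlorophenyl group, and how the two mirror-image forms of compound 4 compare.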